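This account rests on a few compounds, and the source may have more. Where it says the series, first, only, none or still open, it means among the compounds named here.

Compound 1 `C=C1C(=O)O[C@@H]2[C@@H]1C[C@H](OC(C)=O)[C@](C)(O)CC/C=C(\C)CC/C=C(\C)[C@@H]2OC(C)=O` gives the higher of the two numbers in a functional assay on MCF7 cells (Homo sapiens) for cytotoxicity, read by colorimetric assay and MTT assay (a lower number here means a stronger inhibitor, a higher number a weaker inhibitor), at 10.3 ug/mL, while compound 2 `C=C1C(=O)O[C@H]2C[C@]3(C)O[C@H]3CC/C(C)=C/CC/C(C)=C/C[C@H]12` gives 2.3 ug/mL; the gap between them lies beyond the usual scatter. Compound 3 `C=C1C(=O)O[C@H]2C/C(C)=C/CC/C(C)=C/CC[C@@](C)(O)[C@@H](OC(C)=O)C[C@H]12` differs from compound 1 in one place (hydrogen in place of acetoxy on a saturated ring carbon). Going by the values given here, no measured pair here shows this change on its own, so the size of the step is uncertain. Compound 3 is expected to come out somewhat stronger, a step of a 1.5-fold lower number from compound 1 to compound 3 (0.17 log units; within the scatter) that may still fall within the scatter. For compound 3 the value in this assay is estimated at 7 ug/mL, with a range from 3 ug/mL to 16 ug/mL.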

Compound 3, half-maximal inhibitory concentration: > 30 ug/mL
Compound 3 gave a limit, no number; the forecaster's own chance of this, stated with the estimate: 5%; at least 4.2-fold (0.63 log units) between middle value and limit.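

Hydrogen in place of acetoxy on this saturated ring carbon weakens the compound in this assay, with an at least 2.9-fold higher number from compound 1 to compound 3 (0.46 log units; beyond the scatter). In this pair, then, the acetoxy group at this position goes with the stronger inhibition, and its loss is not a small or neutral change. Compound 3 gives > 30 ug/mL, which is a limit and not a number, so the full size of the step cannot be read. The compounds shown leave open whether the acetoxy group itself matters here or whether a hydroxy group, a methoxy group or a longer ester on this carbon would serve as well. They also leave open what the other acetoxy group of compound 1 contributes.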